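The source may hold more compounds than are shown below. What is called first, only, known or untested is meant among the compounds shown, and "the series" means these compounds.

Measured compounds in a functional assay on PC-12 cells (Rattus norvegicus) for cytotoxicity, read by MTT assay, with stated times of 2 h and 24 h, tested at 1 uM; a lower number here means a weaker effect, a higher number a stronger effect of the compound at the concentration tested:

Compound 1, `Oc1cc(C(F)(F)F)ccc1-c1nc(-c2ccccc2O)n(-c2ccc(C(F)(F)F)cc2)n1`, gives 70.7%.
Compound 2, `N#Cc1ccc(-n2nc(-c3ccc(C(F)(F)F)cc3O)nc2-c2ccccc2O)cc1`, gives 66.6%.

Among the compounds with values here, compound 2 stands lowest of the two numbers so far in this assay, and its nearest neighbour is compound 1; the one measured step, a number 4.1 percentage points lower from compound 1 to compound 2 (within the scatter), is within the scatter, so the two compounds cannot be told apart on these numbers. That step replaced trifluoromethyl with cyano on an aromatic carbon.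

Compound 3, `Oc1cc(C(F)(F)F)ccc1-c1nc(-c2ccccc2O)n(-c2ccc(F)cc2F)n1`, has not yet been measured in this assay. It differs from compound 2 as follows: 2,4-difluorophenyl in place of 4-cyanophenyl on an aromatic nitrogen. Within the data shown here, no measured step bears directly on this exchange, since the single step seen, a number 4.1 percentage points lower from compound 1 to compound 2 (within the scatter), changed a group on an aromatic carbon rather than the group on the aromatic nitrogen, and it produced no change beyond the scatter. Among the measured compounds shown here, with only that small step as guidance, compound 3 is expected to land close to compound 2, giving an estimated step of a number 0.4 percentage points higher from compound 2 to compound 3 (within the scatter), with no direction beyond the scatter claimed. The estimate for compound 3 in this assay is therefore 67%, within a range of 55% to 79%.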

Compound 3, a percentage reported as activity, at one concentration (the size of the read-out at that concentration, not a potency): 65.9%
Compound 3: middle estimate off by 1.1 percentage points, on the high side; low and high end bracket the measured number.
By their numbers in this assay, from the lowest: compounds 3, 2 and 1 (each within the scatter of the next).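

The exchange on the aromatic nitrogen of the five-membered ring is now seen directly in this assay: 2,4-difluorophenyl in place of 4-cyanophenyl gives a number 0.7 percentage points lower from compound 2 to compound 3 (within the scatter), and 2,4-difluorophenyl in place of 4-(trifluoromethyl)phenyl gives a number 4.8 percentage points lower from compound 1 to compound 3 (within the scatter). Compound 1, compound 2 and compound 3 therefore cannot be told apart at this single concentration, even though the phenyl group on that nitrogen carries trifluoromethyl, a nitrile or two fluorines, so none of these three groups stands out from the others in this read-out. Nothing available explains why these exchanges leave the read-out within the scatter.

Going by these compounds, it remains open whether a phenyl group bearing an amine or a carboxylic acid, or a pyridine ring or a longer alkyl chain on the same nitrogen, would move the number beyond the scatter. On these data alone, it is equally open whether a methoxy group in place of the hydroxyl of the 2-hydroxyphenyl group would change the reading, since all three compounds share that group.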